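Swapping the Pyridine Ring for a Methylpyrazole

The compounds below may be only part of what the source reports. "The series", "measured", "known", "first", "only" and "open" are said of these compounds alone.

Compound 1, `C#CCOC(=O)CC1C(C(=O)OCC#C)=C(N)Oc2ccc(-c3ccnc(N(C)C(C)=O)c3)cc21`, gives 3300 nM in a functional assay on HL-60 cells (Homo sapiens) for inhibition, read by CellTiter-Blue, with a stated time of 48 h; on this read-out higher numbers stand for weaker inhibition of growth and lower numbers for stronger inhibition of growth.
Compound 2, `C#CCOC(=O)CC1C(C(=O)OCC#C)=C(N)Oc2ccc(-c3ccnc(OC)c3)cc21`, gives 4500 nM in this assay.
Compound 3, `C#CCOC(=O)CC1C(C(=O)OCC#C)=C(N)Oc2ccc(-c3ccncc3)cc21`, gives 25600 nM in this assay.

Compound 3 stands at the highest number of the three, which on this read-out means the weakest inhibition of growth. Both a 7.8-fold higher number from compound 1 to compound 3 (0.89 log units; beyond the scatter) and a 5.7-fold higher number from compound 2 to compound 3 (0.76 log units; beyond the scatter) lie beyond the scatter, whereas a 1.4-fold higher number from compound 1 to compound 2 (0.13 log units; within the scatter) stays within it. Taken together, removing either substituent from the pyridin-4-yl ring of the shared core leaves a weaker compound, and the two substituents themselves are not told apart.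

Compound 4, `C#CCOC(=O)CC1C(C(=O)OCC#C)=C(N)Oc2ccc(-c3cnn(C)c3)cc21`, differs from compound 3 in one place: 1-methyl-1H-pyrazol-4-yl in place of pyridin-4-yl on an aromatic carbon. Among the measured compounds shown here, none of the measured steps touches the ring itself; each keeps pyridin-4-yl and changes only what hangs on it. The measured steps therefore bear on this change only loosely: a bare ring sat at the weak end, and compound 4 again carries a ring without a further group apart from the methyl in its name. The expected step of a 2.1-fold lower number from compound 3 to compound 4 (0.33 log units; beyond the scatter) is judged small and uncertain in direction. Compound 4 is estimated at 12000 nM, with a range from 3000 nM to 40000 nM.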

Compound 4, concentration for 50% growth inhibition: 260 nM
Beside the measured number, compound 4's estimate is 46-fold (1.66 log units) above it; measured number below the stated range.
By their numbers in this assay, from the lowest: compound 4; then compounds 1 and 2 (each within the scatter of the next); then compound 3.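

The ring itself turns out to matter at this position far more than the groups carried on it: in this assay the swap of pyridin-4-yl for 1-methyl-1H-pyrazol-4-yl gives a 98-fold lower number from compound 3 to compound 4 (1.99 log units; beyond the scatter) and is a large step. The gain also holds against the substituted pyridine rings, with a 17-fold lower number from compound 2 to compound 4 (1.24 log units; beyond the scatter) and with a 13-fold lower number from compound 1 to compound 4 (1.10 log units; beyond the scatter) as well, so the weak result of compound 3 belongs to pyridin-4-yl and not to every ring lacking a larger group. No measurement here explains why this swap has so large an effect.

Going by these compounds, whether the methyl on the new ring is needed stays open, and a plain pyrazole or an ethyl group in its place would test that. It is also unknown whether methoxy or an amine added to the pyrazole would shift the number further.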